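The compounds below may be only part of what the source reports. "The series", "measured", "known", "first", "only" and "open" are said of these compounds alone.

Measured so far in an assay on CHO cells with metabotropic glutamate receptor 5 (Homo sapiens) as the target; a higher number here means that more compound is needed for the effect, a lower number that less compound is needed:
Compound 1 `O=C(Nc1cc(-c2ccccc2)nn1-c1ccccc1)c1ccccc1` gives 40 nM.
Compound 2 `O=C(Nc1cc(-c2ccccc2)nn1-c1ccccc1)c1cnccn1` gives 200 nM.
Compound 3 `O=C(Nc1cc(-c2ccccc2)nn1-c1ccccc1)c1ccccc1O` returns only a limit, > 10000 nM.

Compound 3 thus sits at the weak end of the numbers shown, the reported figure being a limit of this assay and not a number (the limit of > 10000 nM in this assay, at which 1 of the 3 values shown sits). Against compound 1 the step is an at least 250-fold higher number from compound 1 to compound 3 (2.39 log units; beyond the scatter); against compound 2 it is an at least 50-fold higher number from compound 2 to compound 3 (1.69 log units; beyond the scatter).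

Compound 4 `O=C(Nc1cc(-c2ccccc2)nn1-c1ccccc1)c1ccc(C(F)(F)F)cc1` differs from compound 3 by 4-(trifluoromethyl)phenyl in place of 2-hydroxyphenyl on a carbonyl carbon. The change removes the hydroxy whose entry gave an at least 250-fold higher number from compound 1 to compound 3 (2.39 log units; beyond the scatter), and compound 2 shows a 5.0-fold higher number from compound 1 to compound 2 (0.70 log units; beyond the scatter) for a ring swap of comparable scope, so a large step back down is expected, an at least 200-fold lower number from compound 3 to compound 4 (2.30 log units; beyond the scatter). Compound 4 is estimated at 50 nM, likely between 15 nM and 250 nM.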

Compound 4, half-maximal effective concentration: 19 nM
Beside the measured number, compound 4's estimate is 2.6-fold (0.42 log units) above it, and the stated range covers the measured number.
By their numbers in this assay, from the lowest: compound 4; then compound 1; then compound 2. At a limit, above all of these: compound 3.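

Trifluoromethyl in place of hydrogen on an aromatic carbon is the only change shown that lowers the number relative to compound 1, a 2.1-fold lower number from compound 1 to compound 4 (0.32 log units; beyond the scatter), so a substituent on this ring need not raise it as the hydroxy of compound 3 does. The 4-(trifluoromethyl)phenyl group also clearly outdoes pyrazin-2-yl on the carbonyl carbon, with an 11-fold lower number from compound 2 to compound 4 (1.02 log units; beyond the scatter). Compound 3 is held at a limit of the assay and not a number, so an at least 520-fold lower number from compound 3 to compound 4 (2.72 log units; beyond the scatter) is only a bound: the limit of > 10000 nM in this assay, at which 1 of the 4 values shown sits.

On these data alone, whether the loss in compound 3 belongs to the hydroxy itself or to where it sits remains open. So does whether the lower number of compound 4 is particular to trifluoromethyl, which a methoxy, an amine or a nitrile on this ring would help to settle.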